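The source may hold more compounds than are shown below. What is called first, only, known or untested is meant among the compounds shown, and "the series" means these compounds.

Among the three compounds measured, compound 1 `N#Cc1ccc(NC(=O)c2cc(-c3ccncc3)ccc2O)cc1` gives the highest number in a functional assay on KG-1 cells (Homo sapiens) for cytotoxicity, read by luminescence and CellTiter-Glo, with a stated time of 3 days (on this read-out lower numbers stand for stronger inhibition and higher numbers for weaker inhibition), at 7990 nM. Its nearest neighbour is compound 3 `O=C(Nc1cc(C(F)(F)F)cc(C(F)(F)F)c1)c1ccc(Br)cc1O`, which in this assay gives 830 nM, and the furthest is compound 2 `N#Cc1ccc(NC(=O)c2ccc(Br)cc2O)c(Cl)c1`, which gives 790 nM; both gaps lie beyond the usual scatter. Compound 4 `N#Cc1ccc(NC(=O)c2cc(Br)ccc2O)cc1` differs from compound 1 by bromo in place of pyridin-4-yl on an aromatic carbon. The bromo group now sits as it does in compound 2 and compound 3, though compound 4 carries neither the chloro of compound 2 nor the two trifluoromethyl groups of compound 3. A sizeable step toward a lower number is therefore expected, with a 5.3-fold lower number from compound 1 to compound 4 (0.73 log units; beyond the scatter), and compound 4 is estimated at 1500 nM, within a range of 600 nM to 4000 nM.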

Compound 4, half-maximal inhibitory concentration: 1290 nM
For compound 4 the middle estimate is 1.2-fold (0.07 log units) above the measured one; the range from low to high includes it.
By their numbers in this assay, from the lowest: compounds 2, 3 and 4 (each within the scatter of the next); then compound 1.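

In this assay, for the compounds shown here, the pair gives the first comparison of compounds differing in one place: on the aromatic carbon para to a hydroxy group, bromo in place of pyridin-4-yl gives a 6.2-fold lower number from compound 1 to compound 4 (0.79 log units; beyond the scatter). This position therefore responds to what it carries, and here a single bromine atom gives the lower number than the six-membered aromatic ring. No measured evidence is available to explain this step. On these data alone, whether phenyl, without the ring nitrogen, would behave like pyridin-4-yl remains open. So does the outcome with an amine at this position.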